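Swapping the pyrazole for phenyl in a sulfone series

The compounds below may be only part of what the source reports. "The series", "measured", "known", "first", "only" and "open" are said of these compounds alone.

Measured compounds:
Compound 1 `NCc1ccc(S(=O)(=O)c2cccc(S(=O)(=O)N3CCC[C@H]3CO)c2)s1` gives 192 ng.h/mL in an ADME assay on the whole organism (Mus musculus) for pharmacokinetics, at a dose of 50 mg/kg by the oral route; on this read-out higher numbers stand for higher exposure at the dose given and lower numbers for lower exposure.
Compound 2 `Cn1cc(-c2cc(S(=O)(=O)c3ccc(CN)s3)ccc2S(C)(=O)=O)cn1` gives 1150 ng.h/mL in this assay.

For the measured compounds named here, compound 2 stands highest of the two numbers measured so far; its nearest neighbour, compound 1, sits a good way lower, and that gap lies beyond the usual scatter. Compound 3 `CS(=O)(=O)c1ccc(S(=O)(=O)c2ccc(CN)s2)cc1-c1ccccc1` has not yet been measured. It differs from compound 2 in one place: phenyl in place of 1-methyl-1H-pyrazol-4-yl on an aromatic carbon. Going by the values given here, no pair of measured compounds shows this kind of change, so there is no measured step to lean on, and the expectation can rest only on the value of compound 2.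

With nothing to point one way or the other, the step from compound 2 to compound 3 in this assay is expected to be modest, a 1.4-fold lower number from compound 2 to compound 3 (0.16 log units; within the scatter), and it may well fall within the scatter. Compound 3 is therefore estimated at 800 ng.h/mL, with a range from 250 ng.h/mL to 2500 ng.h/mL.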

Compound 3, area under the concentration-time curve: 571 ng.h/mL
Compound 3: the middle estimate sits 1.4-fold (0.15 log units) above what was measured, and the stated range covers the measured number.
By their numbers in this assay, from the lowest: compound 1; then compounds 3 and 2 (each within the scatter of the next).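

At this position, ortho to a methylsulfonyl group, this assay now offers its first direct comparison, with a 2.0-fold lower number from compound 2 to compound 3 (0.30 log units; within the scatter) on replacing 1-methyl-1H-pyrazol-4-yl with phenyl. The pair therefore gives no clear sign that the choice between these two aromatic rings matters on this read-out, even though phenyl carries no hetero atoms and no hydrogen-bond acceptors. No measurement here offers an explanation for the two numbers.

On these data alone, it remains open whether a non-aromatic group at this position, such as an amine, a carboxylic acid or a longer chain, would stay within the scatter of compound 2 and compound 3. Also open, as far as these compounds go, is whether the same swap would give a similar result on a different core, since compound 1 differs from both in more than one place.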